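Propoxy to hydrogen on the sulfone series

The compounds below may be only part of what the source reports. "The series", "measured", "known", "first", "only" and "open" are said of these compounds alone.

Among the compounds with values here, in a functional assay on MT4 cells (Homo sapiens) for cytotoxicity (a higher number here means a weaker inhibitor, a lower number a stronger inhibitor), compound 3 (`CCCOc1cc(C)cc(S(=O)(=O)c2cccc(N)c2C#N)c1`) gives 11000 nM, the only number. Compound 1 (`N#Cc1c(N)cccc1S(=O)(=O)c1ccccc1`) stands at > 5000 nM, which is a limit. Compound 2 (`COc1cccc(S(=O)(=O)c2cccc(N)c2C#N)c1`) stands at > 200000 nM, also a limit.

Compound 4 (`Cc1cccc(S(=O)(=O)c2cccc(N)c2C#N)c1`) differs from compound 3 by hydrogen in place of propoxy on an aromatic carbon. Within the data shown here, the only measured step, a step that the two limits leave unreadable from compound 1 to compound 2, gives no size to carry over. Neither compound 1 nor compound 2 carries propoxy, and neither gives a number, so the guide is weak. An expected step of a 4.5-fold higher number from compound 3 to compound 4 (0.66 log units; beyond the scatter) is estimated in this assay, toward a higher number. For compound 4 the estimate is 50000 nM, with an expected range of 12000 nM to 200000 nM.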

Compound 4, half-maximal inhibitory concentration: 179000 nM
The estimate for compound 4 lay 3.6-fold (0.55 log units) below the measured number, and the stated range covers the measured number.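

In this assay, within the data shown here, the change to hydrogen from propoxy gives a 16-fold higher number from compound 3 to compound 4 (1.21 log units; beyond the scatter) as the first step of readable size at this position, and only compound 3 carries propoxy. Compound 2 stands at a limit, and the step of an at least 1.1-fold lower number from compound 2 to compound 4 (0.04 log units; that floor lies within the scatter) rests on that limit: the limit of > 200000 nM in this assay, at which 1 of the 4 values shown sits. The step involving compound 1 cannot be read, as compound 1 also stands at a limit: the limit of > 5000 nM in this assay, at which 1 of the 4 values shown sits.

On these data alone, whether butoxy or an amine on this aromatic carbon would move the number further stays open. As far as these compounds go, whether the propoxy step holds without the methyl group also stays open.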